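The compounds below may be only part of what the source reports. "The series", "measured", "known", "first", "only" and "open" are said of these compounds alone.

Measured so far in a functional assay on CHO cells with sphingosine 1-phosphate receptor 2 (Homo sapiens) as the target, read by GTPgammaS binding; on this read-out higher numbers stand for an effect only at larger amounts of compound and lower numbers for an effect already at smaller amounts:

Compound 1, `Cc1cc(CCC(=O)O)ccc1-c1noc(-c2ccc(OC(C)C)c(C(F)(F)F)c2)n1`, gives > 10000 nM, which is a limit of the assay.
Compound 2, `Cc1cc(CCC(=O)O)ccc1-c1noc(-c2ccc(OC(C)C)c(Cl)c2)n1`, gives > 10000 nM, which is likewise a limit of the assay.

Both measured compounds share one core and differ only in the group sitting on an aromatic carbon of the outer ring. Compound 2 therefore stands at the upper limit of this assay, not at a number: the effect was not reached within the amounts tested, and the limit of > 10000 nM in this assay, at which 2 of the 2 values shown sit, describes where both values sit. The step that the two limits leave unreadable from compound 1 to compound 2 cannot be read for size, as both ends are limits.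

Compound 3, `Cc1cc(-c2nc(-c3ccc(CCC(=O)O)cc3C)no2)ccc1OC(C)C`, is the next member. It differs from compound 2 by methyl in place of chloro on an aromatic carbon, in words a methyl in place of chloro on an aromatic carbon. Among the measured compounds shown here, the only measured step at this position, from trifluoromethyl to chloro, is unreadable, so it gives no direction. With both neighbours at the limit, no shift beyond the scatter is expected in this assay.

Compound 3 is thus estimated at 10000 nM, with a range from 3000 nM to 30000 nM. The expected change, a number no higher from compound 2 to compound 3 (the limit leaves the size open), is estimated to be essentially none.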

Compound 3, half-maximal effective concentration: > 10000 nM
Compound 3: no number, only a limit; the forecaster's own chance of this, stated with the estimate: 70%; the middle value lies on the limit itself.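

In this assay compound 3 gives > 10000 nM, which is a limit and not a number. No step among compound 1, compound 2 and compound 3 can be read, so trifluoromethyl, chloro and methyl cannot be ranked, and all three compounds stand at one point: the limit of > 10000 nM in this assay, at which 3 of the 3 values shown sit.

The compounds shown leave open whether any of them would reach an effect at larger amounts, and how far apart they would then lie.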